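Acetylation of a secondary hydroxyl on two related cores

The compounds below may be only part of what the source reports. "The series", "measured", "known", "first", "only" and "open" are said of these compounds alone.

Three compounds were tested in a functional assay on A549 cells (Homo sapiens) for antiproliferative activity, read by XTT assay, with a stated time of 72 h; a higher number here means a weaker inhibitor, a lower number a stronger inhibitor. Compound 3 `C=C(C)CCC[C@]1(C)C2=CCC[C@](C)(C[C@H](O)C3=CC(=O)OC3O)[C@H]2CC[C@H]1C` gives 3200 nM. Compound 1 `C=C(C)CCC[C@]1(C)C2=CCC[C@](C)(C[C@H](OC(C)=O)C3=CC(=O)OC3O)[C@H]2CC[C@H]1C` carries the change acetyl in place of hydrogen on an oxygen on a saturated carbon and gives 4500 nM, so that a 1.4-fold higher number from compound 3 to compound 1 (0.15 log units; within the scatter). Compound 2 `C=C(C)CC[C@]1(C)C2=CCC[C@](C)(C[C@@H](O)C3=CC(=O)OC3O)[C@H]2CC[C@H]1C` gives 4400 nM; the difference between its core and that of compound 3 is not broken down here, and its number stands within the scatter of both compound 1 and compound 3.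

Compound 4 `C=C(C)CC[C@]1(C)C2=CCC[C@](C)(C[C@@H](OC(C)=O)C3=CC(=O)OC3O)[C@H]2CC[C@H]1C` has not yet been measured. Among the measured compounds shown here, it carries the change (acetyl in place of hydrogen on an oxygen on a saturated carbon), which is the same change, at the same kind of place, as the one made from compound 3 to compound 1. Because a 1.4-fold higher number from compound 3 to compound 1 (0.15 log units; within the scatter) stayed within the scatter, the step from compound 2 to compound 4 is expected to be of similar size, a 1.3-fold higher number from compound 2 to compound 4 (0.10 log units; within the scatter), resting only on that single earlier step. In this assay compound 4 is therefore estimated at 5500 nM, with a likely range from 2500 nM to 12000 nM.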

Compound 4, half-maximal inhibitory concentration: 11100 nM
Estimate against measurement, compound 4: 2.0-fold (0.30 log units) below; the range from low to high includes it.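

On the core of compound 2, the change from hydroxy to acetoxy in this assay gives a 2.5-fold higher number from compound 2 to compound 4 (0.40 log units; beyond the scatter), a step that lies beyond the scatter, whereas the earlier step on the other core stayed within it. This does not show that the change costs more on one core than on the other, and it gives no reason for either step; two steps also set no rule for any further core in the series. What the pair does show is that the number rose on both cores and that the two steps can be read as one effect carried from core to core, with no difference between them beyond what repeated measurement allows: the same change on two cores in this assay, a 1.4-fold higher number (0.15 log units; within the scatter) from compound 3 to compound 1 and a 2.5-fold higher number (0.40 log units; beyond the scatter) from compound 2 to compound 4, 1.8-fold (0.25 log units) apart, within the scatter of two such steps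

The compounds shown leave open whether a group other than acetyl on the same oxygen, such as a longer acyl chain, benzoyl or a methyl ether, would move the number the same way. They also leave open how an amine or a carboxylic acid in place of the hydroxy would read in this assay on either core.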